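Phenoxymethyl to amino(phenyl)methyl: what to expect for stability

The compounds below may be only part of what the source reports. "The series", "measured", "known", "first", "only" and "open" are said of these compounds alone.

Measured compounds:
compound 1, `CC(=O)NC[C@H]1C(=O)N2C(C(=O)O)=C(C(C)(C)C)O[C@H]12` — < 3 h
compound 2, `CC(C)(C)C1=C(C(=O)O)N2C(=O)[C@H](CNC(=O)COc3ccccc3)[C@H]2O1` — 5.7 h

In an ADME assay, in phosphate buffer, at 28 degrees C, at pH 7.0 (a higher number here means that the compound lasts longer, a lower number that the compound disappears faster), compound 2 gives 5.7 h, the only number shown for this series. For compound 1 the result of < 3 h is a limit of the assay rather than a number (the limit of < 3 h in this assay, at which 1 of the 2 values shown sits). Going by the values given here, the single measured step, an at least 1.9-fold higher number from compound 1 to compound 2 (0.27 log units; that floor lies within the scatter), introduced phenoxy in place of hydrogen on a saturated chain carbon bound to a carbonyl carbon.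

Compound 3, `CC(C)(C)C1=C(C(=O)O)N2C(=O)[C@H](CNC(=O)[C@H](N)c3ccccc3)[C@H]2O1`, differs from compound 2 in one place: amino(phenyl)methyl in place of phenoxymethyl on a carbonyl carbon. Among the compounds with values here, no measured step covers this change; the step from compound 1 to compound 2 touched a different group and itself sat at the floor within the scatter. With nothing to point the other way, the expected step of a 1.0-fold lower number from compound 2 to compound 3 (0.02 log units; within the scatter) is none beyond the scatter. Compound 3 is therefore estimated at 5.5 h, within 2.5 h to 12 h.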

Compound 3, half-life: 2.2 h
Compound 3: middle estimate off by 2.5-fold (0.40 log units), on the high side; the whole stated range lies above it.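

Swapping phenoxymethyl for amino(phenyl)methyl on this carbonyl carbon gives a 2.6-fold lower number from compound 2 to compound 3 (0.41 log units; beyond the scatter) in this assay. Going by these compounds alone, this is the first step at this position that can be read as a real change, as the earlier step was only a floor within the scatter. Both groups hold the same count of heavy atoms and the same six-membered aromatic ring of carbon only, so a matching heavy-atom count and ring did not keep the half-life unchanged.

The step from compound 1 to compound 3 cannot be read, as the value of compound 1 is a limit and not a number: the limit of < 3 h in this assay, at which 1 of the 3 values shown sits.

As far as these compounds go, whether the shorter half-life goes with the amine entering or with the ether oxygen leaving stays open, and a benzyl group on the same carbonyl carbon, carrying neither, would help to separate the two.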